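Trifluoromethyl for methyl on the sulfonamide aniline

The source may report more compounds than this note shows. Statements on the series, on what has been measured and on what is new or still open speak of the compounds shown alone.

The series was characterised in an assay on isolated protein for inhibition of Nicotinamide phosphoribosyltransferase (Homo sapiens), read by WST assay, with stated times of 60 min, 5 min and 30 min, in the presence of a further agent that is not named here; on this read-out lower numbers stand for stronger inhibition and higher numbers for weaker inhibition. Compound 1 `O=C(/C=C/c1cccnc1)NCCCc1ccc(S(=O)(=O)Nc2ccccc2)cc1` gives 5920 nM in this assay. Compound 2 `O=C(/C=C/c1cccnc1)NCCCCCCc1ccc(S(=O)(=O)Nc2ccccc2)cc1`, which carries a longer chain between the amide and the sulfonamide-bearing ring, gives 14.4 nM. Compound 3 `Cc1cccc(NS(=O)(=O)c2cccc(CCCCCCNC(=O)/C=C/c3cccnc3)c2)c1` gives 12.3 nM in this assay, the lowest of the three numbers, though its number and that of compound 2 lie within the usual scatter of each other, while the number of compound 1 lies far beyond it.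

Compound 4 `O=C(/C=C/c1cccnc1)NCCCCCCc1cccc(S(=O)(=O)Nc2ccc(C(F)(F)F)cc2)c1` is the next structure. It differs from compound 3 in one place: 4-(trifluoromethyl)phenyl in place of 3-methylphenyl on a sulfonamide nitrogen. For the measured compounds named here, no pair of measured compounds shows this change, so its effect cannot be read from the numbers at hand. The three measured compounds share the same arylsulfonamide unit apart from the methyl of compound 3, and nothing in them speaks for a large shift in either direction.

Compound 4 is therefore expected to give an estimated 15 nM in this assay, with a range from 5 nM to 50 nM. The expected step of a 1.2-fold higher number from compound 3 to compound 4 (0.09 log units; within the scatter) is estimated to stay within the scatter.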

Compound 4, half-maximal inhibitory concentration: 24.5 nM
Estimate against measurement, compound 4: 1.6-fold (0.21 log units) below, and the stated range covers the measured number.
By their numbers in this assay, from the lowest: compounds 3, 2 and 4 (each within the scatter of the next); then compound 1.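

In this assay, for the compounds shown here, 4-(trifluoromethyl)phenyl in place of 3-methylphenyl on a sulfonamide nitrogen gives the first step between compounds that differ in one place, a 2.0-fold higher number from compound 3 to compound 4 (0.30 log units; within the scatter). This shows that the sulfonamide nitrogen can carry the larger aryl group, with three added fluorine atoms and a different substitution pattern on the ring, while the number stays within the scatter. No measurement at hand accounts for this result.

The change alters both the substituent and its place on the ring, so the compounds shown leave open whether either alteration alone would shift the number. They also leave open how this assay would respond to a carboxylic acid or an amine on that ring, or to a simple methyl on the sulfonamide nitrogen in place of the ring.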